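Fixing the configuration of compound 1: working notes

A few compounds are considered here, and "the series" means these few. Any claim that something is new, unique, unknown or untested is made for them only; others in the source may bear on it.

Going by the values given here, in a functional assay for inhibition, with Homo sapiens as the target (on this read-out higher numbers stand for weaker inhibition and lower numbers for stronger inhibition), compound 1 `CC1(c2ccc(C(=N)N)cc2)NC(=O)N(CC(=O)NC(CC(=O)O)c2ccccc2)C1=O` gives 200 nM, the lowest of the two numbers so far. Its nearest neighbour, compound 2 `CC(CC(=O)O)NC(=O)CN1C(=O)NC(C)(c2ccc(C(=N)N)cc2)C1=O`, gives 2000 nM.

Compound 3 `C[C@]1(c2ccc(C(=N)N)cc2)NC(=O)N(CC(=O)N[C@@H](CC(=O)O)c2ccccc2)C1=O` has the same atoms and bonds as compound 1, and the change is the two compounds have the same atoms and bonds; at least one stereo element is drawn with a configuration in one of them and without one in the other: 2 of 3 stereo elements differ; a stereocentre at a saturated ring carbon is drawn without a configuration in compound 1 and R in compound 3; a stereocentre at a saturated chain carbon is drawn without a configuration in compound 1 and S in compound 3. A stereocentre at a saturated ring carbon is drawn without a configuration in compound 1 and R in compound 3. A stereocentre at a saturated chain carbon is likewise drawn without a configuration in compound 1 and S in compound 3.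

Among the compounds with values here, the only measured step, a 10-fold higher number from compound 1 to compound 2 (1.00 log units; beyond the scatter), puts methyl in place of phenyl on a saturated chain carbon. It is beyond the scatter, but it changes a group and not a configuration, so it bears on this question only indirectly. Within the data shown here, no measured pair tests configuration, and a higher number for compound 3 remains possible. A modest move to a lower number is nevertheless expected, a 2.2-fold lower number from compound 1 to compound 3 (0.35 log units; beyond the scatter). In this assay the estimate for compound 3 is 90 nM, with an expected range of 25 nM to 400 nM.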

Compound 3, half-maximal inhibitory concentration: 6000 nM
Estimate against measurement, compound 3: 67-fold (1.82 log units) below; measured number above the stated range.
By their numbers in this assay, from the lowest: compound 1; then compound 2; then compound 3.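

In this assay, going by these compounds alone, configuration alone moves the number at this position, a sensitivity the earlier compounds could not reveal because their only step swapped one group for another: the fact that one of compounds 1 and 3 is drawn with a defined configuration and the other without, at the place where they differ. With no atom or bond changed, the result is a 30-fold higher number from compound 1 to compound 3 (1.48 log units; beyond the scatter), a large step, whereas a 10-fold higher number from compound 1 to compound 2 (1.00 log units; beyond the scatter) is modest. Defining the ring carbon as R and the chain carbon as S therefore does not retain the activity of compound 1, and this particular drawn form of the series sits well above the undefined one on this read-out.

From the compounds shown here alone, it remains open which of the two stereocentres carries the step, and how the other combinations of configuration at the ring carbon and the chain carbon would read in this assay, including whether one of them accounts for the lower number of compound 1. Also open, going by these compounds, is whether a cyclohexyl group in place of the phenyl on the chain carbon would follow the same dependence on configuration.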